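Gem-dimethyl at the acid carbon: compound 4 in the series

The compounds below may be only part of what the source reports. "The series", "measured", "known", "first", "only" and "open" are said of these compounds alone.

Compound 2 `COc1ccc(F)c([C@H]2CC[C@H](COc3cccc([C@H](C4CC4)[C@H](C)C(=O)O)c3)CC2)c1` gives the lowest number among the three measured compounds in a functional assay on HEK293 cells for agonist activity at Free fatty acid receptor 1 (Homo sapiens), read by FLIPR and calcium flux; a lower number here means that less compound is needed, a higher number that more compound is needed for the effect: compound 2 gives 0.2 nM. Compound 1 `COc1ccc(F)c([C@H]2CC[C@H](COc3cccc([C@@H](CC(=O)O)C4CC4)c3)CC2)c1` gives 0.94 nM, and compound 3 `COc1ccc(F)c([C@H]2CC[C@H](COc3cccc([C@H](C4CC4)[C@H](F)C(=O)O)c3)CC2)c1` gives 54 nM. Compound 4 `COc1ccc(F)c([C@H]2CC[C@H](COc3cccc([C@H](C4CC4)C(C)(C)C(=O)O)c3)CC2)c1` carries 1-carboxy-1-methylethyl in place of 1-carboxyethyl on a saturated chain carbon bound to an aromatic carbon and a saturated ring carbon. The step of a 4.7-fold lower number from compound 1 to compound 2 (0.67 log units; beyond the scatter) shows one added methyl at this carbon to be tolerated, whereas a 57-fold higher number from compound 1 to compound 3 (1.76 log units; beyond the scatter) and a 270-fold higher number from compound 2 to compound 3 (2.43 log units; beyond the scatter) show how strongly this carbon responds to substitution. Going by the values given here, no measured step covers a second methyl here, so for compound 4 a modest rise in this assay is expected, a 7.5-fold higher number from compound 2 to compound 4 (0.88 log units; beyond the scatter). Compound 4 is thus estimated at 1.5 nM, with a range from 0.3 nM to 8 nM.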

Compound 4, half-maximal effective concentration: 0.11 nM
Compound 4: the middle estimate sits 14-fold (1.13 log units) above what was measured, outside the stated range (below it).
By their numbers in this assay, from the lowest: compounds 4 and 2 (each within the scatter of the next); then compound 1; then compound 3.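

In this assay, 1-carboxy-1-methylethyl in place of 1-carboxyethyl is tolerated at this carbon: a 1.8-fold lower number from compound 2 to compound 4 (0.26 log units; within the scatter) and leaves the two compounds unordered. Set against the carboxymethyl and carboxy(fluoro)methyl compounds, an 8.5-fold lower number from compound 1 to compound 4 (0.93 log units; beyond the scatter) and a 490-fold lower number from compound 3 to compound 4 (2.69 log units; beyond the scatter) show that the two-methyl arrangement keeps the low number of compound 2, with only the fluoro compound far removed. Nothing measured here explains these differences. Still open, going by these compounds, is whether a longer chain, such as ethyl in place of either methyl, or a cyclopropyl ring closed through both methyl carbons would hold numbers this low.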